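Aryl urea series: ethyl in place of cyano, compound 3

The source may hold more compounds than are shown below. What is called first, only, known or untested is meant among the compounds shown, and "the series" means these compounds.

Measured in a functional assay on MDA-MB-231 cells (Homo sapiens) for cytotoxicity, read by MTT assay, with a stated time of 48 h; a lower number here means a stronger inhibitor, a higher number a weaker inhibitor:
compound 1, `COc1ccc(CN(C(=O)Nc2ccc(C#N)cc2)n2cnnc2)cc1OC`: > 50000 nM
compound 2, `COc1cc(CN(C(=O)Nc2ccc(C#N)cc2)n2cnnc2)cc(OC)c1OC`: > 50000 nM

Compound 1 stands only at a limit of this assay, not at a number. Compound 2 likewise sits at a limit. Among the measured compounds shown here, the one step between them, a step that the two limits leave unreadable from compound 1 to compound 2, therefore cannot be sized; both values rest at the limit of > 50000 nM in this assay, at which 2 of the 2 values shown sit.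

Compound 3, `CCc1ccc(NC(=O)N(Cc2ccc(OC)c(OC)c2)n2cnnc2)cc1`, is not yet measured in this assay. It differs from compound 1 thus: ethyl in place of cyano on an aromatic carbon. For the measured compounds named here, no measured step touches this change; the only step in hand concerns a methoxy on an aromatic carbon and is itself unreadable. Nothing in the shown pairs argues for a move beyond the scatter in either direction, and the starting point is itself a limit rather than a number. The expectation for compound 3 in this assay is a value at or near the same limit, estimated as 50000 nM with a range of 10000 nM to 200000 nM. The step of a number no higher from compound 1 to compound 3 (the limit leaves the size open) expected from this is nominal only, given that it starts from a limit.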

Compound 3, half-maximal inhibitory concentration: > 50000 nM
Compound 3: a limit, no number; the forecaster's own chance of this, stated with the estimate: 70%; the middle value lies on the limit itself.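

In this assay compound 3 gives > 50000 nM, a limit and not a number. Among the compounds shown here, no step among compound 1, compound 2 and compound 3 can be read: the limit of > 50000 nM in this assay, at which 3 of the 3 values shown sit. The compounds shown leave open whether ethyl in place of cyano, or methoxy in place of hydrogen, changes the read-out at all, and how far each compound lies past the limit.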